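Carboxymethyl on the ring nitrogen of compound 2

The source may report more compounds than this note shows. Statements on the series, on what has been measured and on what is new or still open speak of the compounds shown alone.

Compound 2 `Cc1cccc2cc(/C=C3\SC(=S)NC3=O)c(Cl)nc12` is one of three close analogues on a shared core. In a toxicity assay on A549 cells (Homo sapiens) for cytotoxicity, read by MTT assay, with a stated time of 48 h (on this read-out lower numbers stand for stronger inhibition of growth and higher numbers for weaker inhibition of growth), compound 2 gives > 100 ug/mL, which is a limit of the assay and not a number. Compound 1 `CCOc1ccc2nc(Cl)c(/C=C3\SC(=S)NC3=O)cc2c1` likewise gives only a limit, > 100 ug/mL. Compound 3 `COc1ccc2cc(/C=C3\SC(=S)NC3=O)c(Cl)nc2c1` also sits at a limit, with > 100 ug/mL. Among the measured compounds shown here, no measured step between these compounds exists: the limit of > 100 ug/mL in this assay, at which 3 of the 3 values shown sit, so compound 2 can be placed neither above nor below compound 1 or compound 3, only at the same limit.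

Compound 4 `Cc1cccc2cc(/C=C3\SC(=S)N(CC(=O)O)C3=O)c(Cl)nc12` differs from compound 2 in one place: carboxymethyl in place of hydrogen on an amide-type nitrogen in a ring. No step between measured compounds is available to gauge this change, and none of the measured analogues has shown growth inhibition within the range of this assay. The expected step is a number no higher from compound 2 to compound 4 (the limit leaves the size open), that is, none beyond the scatter. Compound 4 is accordingly estimated at 100 ug/mL, with a range from 50 ug/mL to 200 ug/mL, a further limit rather than a number being the likelier outcome.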

Compound 4, concentration for 50% growth inhibition: > 100 ug/mL
Compound 4 gave a limit, no number; the forecaster's own chance of this, stated with the estimate: 70%; the middle value sits exactly at the limit.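

In this assay compound 4 gives > 100 ug/mL, a limit and not a number. Compound 2 gives > 100 ug/mL, also a limit. Among the compounds shown here, no step between compound 2 and compound 4 can be read: the limit of > 100 ug/mL in this assay, at which 4 of the 4 values shown sit. The compounds shown leave open whether carboxymethyl in place of hydrogen on the ring nitrogen changes growth inhibition at all.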